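Anticonvulsant series: replacing heptyl on the ring nitrogen side chain

This account rests on a few compounds, and the source may have more. Where it says the series, first, only, none or still open, it means among the compounds named here.

Measured so far:
compound 1 `CCCCCCCCN1C(=O)CCc2cc(-n3cnnc3)ccc21` — 300 mg/kg
compound 2 `O=C1CCc2cc(-n3cnnc3)ccc2N1Cc1ccccc1F` — 300 mg/kg
compound 3 `O=C1CCc2cc(-n3cnnc3)ccc2N1Cc1ccc(Cl)cc1Cl` — 300 mg/kg

In a functional assay on the whole organism (strain KunMing) with Mus musculus as the target, in the maximal electroshock model, with a stated time of 4 h (on this read-out lower numbers stand for an effect already at smaller amounts and higher numbers for an effect only at larger amounts of compound), compound 1 gives 300 mg/kg, level with compounds 2 and 3 at the digits shown. Two steps exchange the heptyl of compound 1 for an aromatic group: no change at the digits printed from compound 1 to compound 2 (within the scatter) and no change at the digits printed from compound 1 to compound 3 (within the scatter). The third step, no change at the digits printed from compound 2 to compound 3 (within the scatter), exchanges one aromatic group for another. Compound 4 `O=C1CCc2cc(-n3cnnc3)ccc2N1Cc1ccc(F)cc1` differs from compound 1 by 4-fluorophenyl in place of heptyl on a saturated chain carbon bound to an amide-type nitrogen in a ring. Both aryl-for-heptyl steps bear directly on this change, and neither moved the read-out beyond the scatter. No step beyond the scatter is therefore expected here; no change at the digits printed from compound 1 to compound 4 (within the scatter) is the estimated step. Compound 4 is expected to give 300 mg/kg in this assay, with a range from 150 mg/kg to 600 mg/kg.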

Compound 4, minimum effective dose: 300 mg/kg
The estimate for compound 4 equals the measured number at the digits printed; the measured number falls inside the stated range.
By their numbers in this assay, from the lowest: compounds 1, 2, 3 and 4 (each within the scatter of the next).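

Notes on the series: the step of no change at the digits printed from compound 1 to compound 4 (within the scatter) adds a third aromatic replacement for heptyl on a saturated chain carbon bound to an amide-type nitrogen in a ring. The fluorine-bearing groups also give no change at the digits printed from compound 2 to compound 4 (within the scatter), and the exchange of the dichlorinated group gives no change at the digits printed from compound 3 to compound 4 (within the scatter), so 2-fluorophenyl, 2,4-dichlorophenyl and 4-fluorophenyl cannot be told apart here.

Open, on these data alone, is whether an amine, a carboxylic acid or a chain shorter than heptyl at this place would give a step beyond the scatter. No supporting measurement bears on this result.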